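This account rests on a few compounds, and the source may have more. Where it says the series, first, only, none or still open, it means among the compounds named here.

Working notes on the series. Compound 1 `COc1cc(C(=O)C2Sc3nnc(-c4cc(OC)c(OC)c(OC)c4)n3NC2c2ccco2)cc(OC)c1OC`, compound 2 `COc1cc(-c2nnc3n2NC(c2ccco2)C(C(=O)c2cccs2)S3)cc(OC)c1OC` and compound 3 `COc1cc(-c2nnc3n2NC(c2ccco2)C(C(=O)c2ccc(Cl)cc2)S3)cc(OC)c1OC` share one core and differ only in the group on the carbonyl carbon. In a functional assay on MCF7 cells (Homo sapiens) for cytotoxicity, read by MTT assay, with a stated time of 48 h (on this read-out lower numbers stand for stronger inhibition and higher numbers for weaker inhibition), compound 1 reaches only a limit of the assay, > 100000 nM. In this assay compound 2 likewise gives only a limit, > 100000 nM. Compound 3 also stops at a limit in this assay, > 100000 nM. Where compound 3 stands is thus known only as a limit, and the two other values shown are limits too: the limit of > 100000 nM in this assay, at which 3 of the 3 values shown sit. The three steps between the measured compounds, a step that the two limits leave unreadable from compound 1 to compound 2, a step that the two limits leave unreadable from compound 1 to compound 3 and a step that the two limits leave unreadable from compound 2 to compound 3, cannot be sized for that reason.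

Compound 4 `COc1cc(-c2nnc3n2NC(c2ccco2)C(C(=O)c2ccc(F)cc2)S3)cc(OC)c1OC` has not been measured. It differs from compound 3 by fluoro in place of chloro on an aromatic carbon. Among the compounds with values here, the steps that bear on it are the three exchanges of the group on the carbonyl carbon, none of which could be read; no measured step shows whether a halogen swap on this ring changes anything. With every value shown resting at a limit, compound 4 is expected to remain at or near that limit in this assay. The expected step is a step that the limit leaves unreadable from compound 3 to compound 4. The estimate for compound 4 in this assay is 150000 nM, within a range from 50000 nM to 500000 nM.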

Compound 4, half-maximal inhibitory concentration: > 100000 nM
Compound 4: only a limit was reported; the forecaster's own chance of this, stated with the estimate: 85%; the middle value does not contradict the limit.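

In this assay no new step can be read: compound 4 also stops at a limit, so its steps to compound 1, compound 2 and compound 3 cannot be sized. The values shown all rest at one limit: the limit of > 100000 nM in this assay, at which 4 of the 4 values shown sit. The compounds shown leave open whether fluoro, chloro or any carbonyl group changes cytotoxicity at all.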